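The compounds below may be only part of what the source reports. "The series", "measured", "known", "first", "only" and "open" are said of these compounds alone.

Compound 2, `COc1cccc2c1c(NS(=O)(=O)c1ccc(Cl)s1)nn2Cc1cc(CNC(C)=O)ccn1`, gives the higher of the two numbers recorded in a functional assay on CHO cells for antagonist activity at C-C chemokine receptor type 4 (Homo sapiens), read by GTPgammaS binding (on this read-out lower numbers stand for stronger inhibition and higher numbers for weaker inhibition), namely 158 nM. Compound 1, `COc1cccc2c1c(NS(=O)(=O)c1ccc(Cl)s1)nn2Cc1cccc(CNC(=O)C2CCOCC2)c1`, gives 31.6 nM in this assay; the two compounds differ in more than one place, so the two values are simply noted side by side, with compound 2 the weaker inhibitor.

Compound 3, `COc1cccc2c1c(NS(=O)(=O)c1ccc(Cl)s1)nn2Cc1cccc(CNC(C)=O)n1`, carries the same atoms as compound 2, joined differently: 6-(acetamidomethyl)pyridin-2-yl in place of 4-(acetamidomethyl)pyridin-2-yl on a saturated chain carbon bound to an aromatic nitrogen. For the measured compounds named here, no pair of measured compounds shows what such a rearrangement does in this assay, so the step from compound 2 cannot be read from any measured neighbour. The expectation is that it stays within the usual scatter, with no clear direction; the estimate is a step of a 1.3-fold higher number from compound 2 to compound 3 (0.10 log units; within the scatter). Compound 3 is therefore expected to give about 200 nM in this assay, in a range from 60 nM to 700 nM.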

Compound 3, half-maximal inhibitory concentration in the C-C chemokine receptor type 4 assay: 126 nM
Compound 3: the middle estimate sits 1.6-fold (0.20 log units) above what was measured; the range from low to high includes it.
By their numbers in the C-C chemokine receptor type 4 assay, from the lowest: compound 1; then compounds 3 and 2 (each within the scatter of the next).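

For the compounds shown here, in the C-C chemokine receptor type 4 assay, compound 2 gives 158 nM and compound 3 gives 126 nM; this is the first exchange at this position that can be read on its own: a 1.3-fold lower number from compound 2 to compound 3 (0.10 log units; within the scatter), with 6-(acetamidomethyl)pyridin-2-yl in place of 4-(acetamidomethyl)pyridin-2-yl on a saturated chain carbon bound to an aromatic nitrogen. For this pair, therefore, the rearrangement of the same atoms produces no change that can be told apart from the scatter of the measurement. No information is at hand that would explain this result. In a physicochemical assay for acid dissociation, compound 2 is recorded as "not determined" (no result reported) and compound 3 as "not determined" (no result reported), so no comparison can be made there.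

Compound 1 differs from both compound 2 and compound 3 in more than one place, so no single change can be linked to its separation from them. Going by these compounds, it remains open whether a primary amine or a carboxylic acid in place of the acetamide would leave the two arrangements equally indistinguishable.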